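The source may report more compounds than this note shows. Statements on the series, on what has been measured and on what is new or still open speak of the compounds shown alone.

Measured in an ADME assay on BE(2)-C cells (Homo sapiens) for cytotoxicity, read by MTT assay, with a stated time of 20 h; on this read-out higher numbers stand for lower toxicity in this test and lower numbers for higher toxicity in this test:
- Compound 1 `CN1CCN(C(=O)C2CCN(C(=O)c3cc4ccccc4n3Cc3ccc(Cl)cc3)CC2)CC1`: 75600 nM
- Compound 2 `O=C(c1cc2ccccc2n1Cc1ccc(Cl)cc1)N1CCC(C(=O)N2CCCC2)CC1`: 65600 nM
- Compound 3 `CN(Cc1ccccc1)C(=O)C1CCN(C(=O)c2cc3ccccc3n2Cc2ccc(Cl)cc2)CC1`: 87000 nM

Compound 3 stands level with the other two compounds. The steps among the three are a 1.2-fold higher number from compound 1 to compound 3 (0.06 log units; within the scatter), a 1.3-fold higher number from compound 2 to compound 3 (0.12 log units; within the scatter) and a 1.2-fold lower number from compound 1 to compound 2 (0.06 log units; within the scatter), all within the usual scatter of repeated measurements.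

Compound 4 `CN(Cc1ccccc1)C(=O)C1CCN(C(=O)c2cc3ccccc3n2Cc2ccc(C(F)(F)F)cc2)CC1` has trifluoromethyl in place of chloro on an aromatic carbon, para to a large group: trifluoromethyl in place of chloro on an aromatic carbon. Among the compounds with values here, none of the measured steps touches this position. All three swap only the group on a carbonyl carbon, so they bear on the new change only indirectly. They show that the number held steady across those swaps, but they say nothing directly about losing chloro. With no direct evidence, no direction can be argued, and no step beyond the scatter is expected. The expected result is a 1.1-fold lower number from compound 3 to compound 4 (0.04 log units; within the scatter). For compound 4 the estimated value is 80000 nM, with an expected range from 40000 nM to 150000 nM.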

Compound 4, half-maximal cytotoxic concentration: 90300 nM
Compound 4: middle estimate off by 1.1-fold (0.05 log units), on the low side; measured number inside the range.
By their numbers in this assay, from the lowest: compounds 2, 1, 3 and 4 (each within the scatter of the next).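

In this assay there is a 1.0-fold higher number from compound 3 to compound 4 (0.02 log units; within the scatter) for the one step shown that touches this aromatic carbon rather than the group on a carbonyl carbon. The earlier compounds shown here could speak only to that other site, so this pair adds direct evidence from the 4-chlorobenzyl side of the molecule. There, replacing chloro, with 1 heavy atom, by trifluoromethyl, with 4 heavy atoms, leaves the two compounds level in this test.

The compounds shown leave open whether a different kind of group on this aromatic carbon, such as an amine or a carboxylic acid, would also leave the number level, and whether the same swap would behave alike with pyrrolidin-1-yl or 4-methylpiperazin-1-yl on the carbonyl carbon. No measurement at hand offers an explanation for this result.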